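Ethoxy in Place of Methyl: Expected Cytotoxicity of Compound 4

The source may report more compounds than this note shows. Statements on the series, on what has been measured and on what is new or still open speak of the compounds shown alone.

Compound 2 `Cc1ccc2nc(Nc3nc4ccccc4s3)sc2c1` is one of three measured members of a shared core. In a functional assay on B16-F10 cells (Mus musculus) for cytotoxicity, read by MTT assay, with a stated time of 48 h (a higher number here means a weaker inhibitor, a lower number a stronger inhibitor), compound 2 gives > 50000 nM, which is a limit of the assay and not a number. Compound 1 `S=C(Nc1ccc(Cl)cc1)Nc1nc2ccccc2s1` gives > 50000 nM in this assay, again a limit. Compound 3 `Cc1ccc2nc(Nc3nc4ccc(F)cc4s3)sc2c1` gives 29600 nM in this assay. Going by the values given here, the only measured single change, an at least 1.6-fold lower number from compound 2 to compound 3 (0.22 log units; that floor lies within the scatter), is bounded in its size by the limit of > 50000 nM in this assay, at which 2 of the 3 values shown sit. Compound 4 `CCOc1ccc2nc(Nc3nc4ccccc4s3)sc2c1` differs from compound 2 by ethoxy in place of methyl on an aromatic carbon. Among the compounds with values here, no measured step involves an alkoxy for alkyl exchange, so compound 4 is expected to remain close to compound 2, with a step that the limit leaves unreadable from compound 2 to compound 4 expected to fall within the scatter. Compound 4 is therefore estimated at 70000 nM, between 30000 nM and 200000 nM.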

Compound 4, half-maximal inhibitory concentration: > 50000 nM
Compound 4 ended at the assay's limit (the forecaster's own chance of this, stated with the estimate: 70%); the middle value is on the limit's open side.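

No step can be read between compound 2 and compound 4, since both end at a limit of the assay: the limit of > 50000 nM in this assay, at which 3 of the 4 values shown sit. In this assay the compounds shown leave open whether ethoxy in place of methyl on an aromatic carbon changes the reading at all.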